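A few compounds are considered here, and "the series" means these few. Any claim that something is new, unique, unknown or untested is made for them only; others in the source may bear on it.

Compound 1 `C/C=C/C(=O)Nc1cccc(Oc2nc(Nc3cccc(OC)c3)nc3c2CSCC3)c1`: > 50000 nM
Compound 2 `CC/C=C/C(=O)Nc1cccc(Oc2nc(Nc3cccc(OC)c3)nc3c2CSCC3)c1`: > 50000 nM
Compound 3 `CCC/C=C/C(=O)Nc1cccc(Oc2nc(Nc3cccc(OC)c3)nc3c2CSCC3)c1`: > 50000 nM

All three entries come from an ADME assay on L02 cells (Homo sapiens) for cytotoxicity, read by MTT assay, with a stated time of 72 h (a higher number here means a weaker inhibitor, a lower number a stronger inhibitor), and each is a limit of the assay rather than a number. Compound 1 therefore has no exact position on the scale, and the evidence shows (the limit of > 50000 nM in this assay, at which 3 of the 3 values shown sit).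

Compound 4 `C/C=C/C(=O)Nc1cccc(Oc2nc(Nc3cccc(C#N)c3)nc3c2CSCC3)c1` keeps the core of compound 1 and changes one group: cyano in place of methoxy on an aromatic carbon. In words, cyano takes the place of methoxy on an aromatic carbon, so 3-methoxyphenyl becomes 3-cyanophenyl.

Going by the values given here, no measured step makes this change. The nearest ones are a step that the two limits leave unreadable from compound 1 to compound 2, a step that the two limits leave unreadable from compound 1 to compound 3 and a step that the two limits leave unreadable from compound 2 to compound 3. These steps alter a saturated chain, not the aromatic carbon, and none has a readable size. They offer no direct guide to the effect of replacing methoxy with cyano.

Among the compounds with values here, the only anchor is compound 1, whose entry of > 50000 nM is a limit. On that slender basis, no change beyond the usual scatter is expected, and the estimated step is a number no higher from compound 1 to compound 4 (the limit leaves the size open). Compound 4 is estimated at 50000 nM, with an expected range from 20000 nM to 100000 nM.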

Compound 4, half-maximal inhibitory concentration: > 50000 nM
Compound 4 was reported as a limit; the forecaster's own chance of this, stated with the estimate: 70%; the middle value sits exactly at the limit.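

In this assay compound 4 gives > 50000 nM, a limit of the assay and not a number. Compound 1 gives > 50000 nM, also a limit, so no step can be read between compound 1 and compound 4. The compounds shown leave open where each truly falls on the scale, and whether cyano in place of methoxy changes the value at all: the limit of > 50000 nM in this assay, at which 4 of the 4 values shown sit.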